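Growth inhibition series: the step from compound 2 to compound 3

The source may hold more compounds than are shown below. What is called first, only, known or untested is meant among the compounds shown, and "the series" means these compounds.

Measured in an ADME assay on L132 cells (Homo sapiens) for inhibition, read by MTT assay, with a stated time of 72 h; a lower number here means a stronger inhibitor of growth, a higher number a weaker inhibitor of growth:
- compound 1 `Nc1n[nH]c2cccc(C#Cc3cccc(NC(=O)c4cccc(C(F)(F)F)c4)c3)c12`: > 100000 nM
- compound 2 `Cc1ccc(C(=O)Nc2cccc(C#Cc3cccc4[nH]nc(N)c34)c2)cc1C(F)(F)F`: > 100000 nM

Compound 2 gives > 100000 nM, which is a limit and not a number. Compound 1 also gives > 100000 nM, again a limit. The measured series therefore amounts to the limit of > 100000 nM in this assay, at which 2 of the 2 values shown sit.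

Compound 3 `CN1CCN(c2ccc(C(=O)Nc3cccc(C#Cc4cccc5[nH]nc(N)c45)c3)cc2C(F)(F)F)CC1` is not yet measured. It has 4-methylpiperazin-1-yl in place of methyl on an aromatic carbon, ortho to a trifluoromethyl group: 4-methylpiperazin-1-yl in place of methyl on an aromatic carbon.

Going by the values given here, the only measured step, a step that the two limits leave unreadable from compound 1 to compound 2, supplies no size to carry over. With compound 2 at the limit of > 100000 nM, the only readable direction in this assay is toward stronger inhibition of growth. The expected change is an at least 1.4-fold lower number from compound 2 to compound 3 (0.15 log units; that floor lies within the scatter), an estimate with wide margins.

For compound 3 the estimated value is 70000 nM, with an expected range of 15000 nM to 200000 nM.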

Compound 3, concentration for 50% growth inhibition: > 10000 nM
Compound 3 was reported as a limit; the forecaster's own chance of this, stated with the estimate: 55%; the middle value does not contradict the limit.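

In this assay compound 3 gives > 10000 nM, which is a limit and not a number. Going by these compounds alone, no step from compound 1 or compound 2 to compound 3 can be read. The compounds shown leave open where the actual value of any of the three lies in this assay.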